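Cytotoxicity of three sulfonamide analogues and a cyano replacement

The source may report more compounds than this note shows. Statements on the series, on what has been measured and on what is new or still open speak of the compounds shown alone.

The measured compounds and their values:
Compound 1 `O=C1c2sccc2N(Cc2ccccc2Cl)S(=O)(=O)N1Cc1ccccc1` in an ADME assay on MT4 cells (Homo sapiens) for cytotoxicity, read by MTT assay, with a stated time of 4 days (on this read-out lower numbers stand for higher toxicity in this test and higher numbers for lower toxicity in this test), gives > 298000 nM, a limit of the test rather than a number.
Compound 2 `O=C1c2sccc2N(Cc2ccccc2Br)S(=O)(=O)N1Cc1ccccc1` in this assay gives > 270000 nM, also a limit.
Compound 3 `O=C1c2sccc2N(Cc2cccc(Cl)c2)S(=O)(=O)N1Cc1ccccc1` in this assay gives > 298000 nM, again a limit.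

Compound 3 therefore stands among three values that are all limits: two sit at the limit of > 298000 nM in this assay, at which 2 of the 3 values shown sit, and one at the limit of > 270000 nM in this assay, at which 1 of the 3 values shown sits. The steps a step that the two limits leave unreadable from compound 1 to compound 2, a step that the two limits leave unreadable from compound 1 to compound 3 and a step that the two limits leave unreadable from compound 2 to compound 3 cannot be read in size, since both ends of each are limits.

Compound 4 `N#Cc1cccc(CN2c3ccsc3C(=O)N(Cc3ccccc3)S2(=O)=O)c1` differs from compound 3 by cyano in place of chloro on an aromatic carbon. None of the measured steps gives a readable size, so the only guide is that every compound shown remains a limit in this assay. The expected step that the limit leaves unreadable from compound 3 to compound 4 is accordingly one of no readable change. Compound 4 is estimated at 300000 nM, within 150000 nM to 600000 nM, most likely reported once more as a limit.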

Compound 4, half-maximal cytotoxic concentration: > 305000 nM
Compound 4: a limit, no number; the forecaster's own chance of this, stated with the estimate: 80%; middle value at least 1.0-fold (0.00 log units) from the limit.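

In this assay compound 4 gives > 305000 nM, a limit and not a number. Its steps from compound 1, compound 2 and compound 3 cannot be read, with limits at both ends of each. The compounds shown leave open what concentration, if any, produces cytotoxicity with any of these four compounds.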